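Swapping piperazin-1-yl for isopropoxy on the shared core

A few compounds are considered here, and "the series" means these few. Any claim that something is new, unique, unknown or untested is made for them only; others in the source may bear on it.

Compound 1 `CC(C)(C)n1cc2c(n1)C(=O)CC1(CCN(C(=O)c3cc(-c4ccccc4)nc4ccccc34)CC1)O2` gives 2110 nM
Compound 2 `COc1ccc(-c2cc(C(=O)N3CCC4(CC3)CC(=O)c3nn(C(C)(C)C)cc3O4)c3ccccc3n2)cc1OC` gives 1560 nM
Compound 3 `CC(C)(C)n1cc2c(n1)C(=O)CC1(CCN(C(=O)c3cc(N4CCNCC4)nc4ccccc34)CC1)O2` gives 8570 nM

These three values come from a functional assay on HepG2 cells (Homo sapiens) for inhibition, read by MTT assay, with a stated time of 72 h (on this read-out lower numbers stand for stronger inhibition and higher numbers for weaker inhibition), and compound 3 has the highest number of the three, so it inhibits most weakly here. Compound 4 `CC(C)Oc1cc(C(=O)N2CCC3(CC2)CC(=O)c2nn(C(C)(C)C)cc2O3)c2ccccc2n1` has not yet been measured. It has isopropoxy in place of piperazin-1-yl on an aromatic carbon next to the ring nitrogen: isopropoxy in place of piperazin-1-yl on an aromatic carbon.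

Two measured steps change the group at this same place, and both are modest but beyond the scatter: a 4.1-fold higher number from compound 1 to compound 3 (0.61 log units; beyond the scatter) and a 5.5-fold higher number from compound 2 to compound 3 (0.74 log units; beyond the scatter). In each, piperazin-1-yl comes with the higher number. The step between the other two groups, a 1.4-fold lower number from compound 1 to compound 2 (0.13 log units; within the scatter), stays within the scatter. Isopropoxy has not been tested here, so these steps are only a guide. A modest drop, somewhat smaller than those two steps, is therefore expected. The expected step is a 2.9-fold lower number from compound 3 to compound 4 (0.46 log units; beyond the scatter) in this assay. For compound 4 the estimated value is 3000 nM, with an expected range from 1400 nM to 6500 nM.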

Compound 4, half-maximal inhibitory concentration: 3150 nM
For compound 4 the middle estimate is 1.1-fold (0.02 log units) below the measured one; low and high end bracket the measured number.
By their numbers in this assay, from the lowest: compounds 2, 1 and 4 (each within the scatter of the next, the first and the last beyond it); then compound 3.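

Every group seen earlier at this position carried a ring and isopropoxy has none, yet in this assay it cannot be told apart from phenyl (a 1.5-fold higher number from compound 1 to compound 4 (0.17 log units; within the scatter)), so a ring here is not required to reach the number of compound 1. Replacing piperazin-1-yl with isopropoxy also lowers the number (a 2.7-fold lower number from compound 3 to compound 4 (0.43 log units; beyond the scatter)), which shows that the high number of compound 3 does not follow from every group without an aromatic ring. 3,4-Dimethoxyphenyl still keeps a modest edge over isopropoxy (a 2.0-fold higher number from compound 2 to compound 4 (0.31 log units; beyond the scatter)).

Isopropoxy and piperazin-1-yl differ at once in ring, heavy atoms and hydrogen-bond donor, and the compounds shown leave open which of these goes with the shift. Morpholin-4-yl or a plain methoxy at this position could help separate them. Nothing shown gives a reason for any of these steps.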